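Swapping the Aryl Sulfonate Ester: Methoxy Gives Way to Chlorine

This account rests on a few compounds, and the source may have more. Where it says the series, first, only, none or still open, it means among the compounds named here.

The measured compounds:
compound 1, `COc1ccccc1OS(=O)(=O)c1ccc(N2CCN(C)C2=O)cc1`: 26000 nM
compound 2, `CN1CCN(c2ccc(S(=O)(=O)Oc3c(Cl)cc(Cl)cc3Cl)cc2)C1=O`: 2500 nM
compound 3, `COc1cc(OS(=O)(=O)c2ccc(N3CCN(C)C3=O)cc2)cc(OC)c1OC`: 62 nM

All three share a core bearing a sulfonate ester, and they differ only in the phenyl ring attached through the ester oxygen. In a functional assay on HT-29 cells (Homo sapiens) for antiproliferative activity, read by sulforhodamine B assay, with a stated time of 48 h (on this read-out lower numbers stand for stronger inhibition and higher numbers for weaker inhibition), compound 1 gives 26000 nM, the highest number of the three and so the weakest inhibition of cell growth. Compound 2 gives a clearly lower number, beyond the scatter, and compound 3 gives a far lower number still.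

Compound 4, `CN1CCN(c2ccc(S(=O)(=O)Oc3ccc(Cl)cc3)cc2)C1=O`, has not yet been measured. Compared with compound 1, the change is 4-chlorophenyl in place of 2-methoxyphenyl on an oxygen.

Compound 2, whose ester-side phenyl also carries chlorine, gives 2500 nM in this assay, so a chlorine-bearing phenyl at this position has gone with a lower number than the 2-methoxyphenyl of compound 1. Compound 4 carries a less heavily chlorinated phenyl than compound 2, so the expectation is a number between those two. The step from compound 1 to compound 4 is expected to be a 3.3-fold lower number from compound 1 to compound 4 (0.51 log units; beyond the scatter), downward and beyond the scatter, though not as large as that seen with compound 2. Compound 4 is therefore estimated at 8000 nM, with a plausible range from 2000 nM to 30000 nM.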

Compound 4, half-maximal inhibitory concentration: 12000 nM
Compound 4: the middle estimate sits 1.5-fold (0.18 log units) below what was measured; measured number inside the range.
By their numbers in this assay, from the lowest: compound 3; then compound 2; then compound 4; then compound 1.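

Going by these compounds alone, earlier, no two measured compounds differed in only one place, so this is the first direct read on the phenyl ring attached to the ester oxygen: in this assay, the change gives a 2.2-fold lower number from compound 1 to compound 4 (0.34 log units; beyond the scatter). Within the data shown here, the shared core stays the same, so this modest shift belongs to the exchange of 2-methoxyphenyl for 4-chlorophenyl, and it shows that the number responds to this ring even when only one group on it is exchanged, although this single step cannot separate the effect of the new group from that of its new place on the ring. Nothing available here gives a measured property or other finding that explains why the number moved in this direction.

The compounds shown leave open whether 2-chlorophenyl or 4-methoxyphenyl would behave like compound 4 or like compound 1, a pair that would pull apart the identity of the group and its place on the ring. They also leave open how this ring would respond to an amine, a carboxylic acid or a longer alkoxy chain in place of the chlorine of compound 4.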